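Swapping the aryl ring of compound 3 for pyrazine

The compounds below may be only part of what the source reports. "The series", "measured", "known", "first", "only" and "open" are said of these compounds alone.

Three carbamates sharing one core have been measured in an assay on isolated protein for inhibition of acid ceramidase (Homo sapiens), read by LC-MS, with a stated time of 1 h; a lower number here means a stronger inhibitor, a higher number a weaker inhibitor. Compound 1 `O=C(NCCCCc1ccccc1)n1cc(-c2ccc(Cl)cc2)oc1=O` gives 83 nM, compound 2 `COc1ccc(-c2cn(C(=O)NCCCCc3ccccc3)c(=O)o2)cc1` gives 400 nM, and compound 3 `COc1cc(-c2cn(C(=O)NCCCCc3ccccc3)c(=O)o2)ccc1F` gives 80 nM. Compound 3 thus holds the lowest of the three numbers, but compound 1 sits within the scatter of it, so the two cannot be ordered; only compound 2 stands apart, with a 5.0-fold lower number from compound 2 to compound 3 (0.70 log units; beyond the scatter) and a 4.8-fold higher number from compound 1 to compound 2 (0.68 log units; beyond the scatter). Compound 4 `O=C(NCCCCc1ccccc1)n1cc(-c2cnccn2)oc1=O` differs from compound 3 in one place: pyrazin-2-yl in place of 4-fluoro-3-methoxyphenyl on an aromatic carbon. For the measured compounds named here, none of the measured steps exchanges the whole ring for a nitrogen-containing one; they only vary substituents on a carbon ring, and even those moved this assay by modest amounts. The change here is larger, and the author expects a weakening of moderate size, a 3.8-fold higher number from compound 3 to compound 4 (0.57 log units; beyond the scatter), with wide uncertainty. Compound 4 is therefore estimated at 300 nM, within a range of 60 nM to 1500 nM.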

Compound 4, half-maximal inhibitory concentration: 32 nM
For compound 4 the middle estimate is 9.4-fold (0.97 log units) above the measured one, and the stated range ends above it.
By their numbers in this assay, from the lowest: compound 4; then compounds 3 and 1 (each within the scatter of the next); then compound 2.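

In this assay, for the compounds shown here, the earlier compounds varied only substituents on a ring of carbon only, whereas compound 4 shows that this place, next to the ring oxygen, also accepts a six-membered aromatic ring with 2 hetero atoms. The exchange gives a 2.5-fold lower number from compound 3 to compound 4 (0.40 log units; beyond the scatter) and also a 2.6-fold lower number from compound 1 to compound 4 (0.41 log units; beyond the scatter) so the number falls beyond the scatter against both of the best carbon-ring compounds. The largest step of the series, a 13-fold lower number from compound 2 to compound 4 (1.10 log units; beyond the scatter) shows that neither chloro, nor fluoro with methoxy, is needed for a low number here. Nothing available explains why pyrazin-2-yl gives this result.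

The compounds shown leave open whether both ring nitrogens are needed, which a pyridin-2-yl group would test. They also leave open whether an amine or a methyl group on the pyrazine ring would keep this number.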